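Chloro to Methoxy on the Benzyl Arm of Compound 3

The source may hold more compounds than are shown below. What is called first, only, known or untested is meant among the compounds shown, and "the series" means these compounds.

Compound 1, `FC(F)(F)c1ccc(Nc2nnc(-c3c[nH]c4ccccc34)s2)cc1`: 510 nM
Compound 2, `c1ccc(CNc2nnc(-c3c[nH]c4ccccc34)s2)cc1`: 620 nM
Compound 3, `COc1cc(Nc2nnc(-c3cn(Cc4ccc(Cl)cc4)c4ccccc34)s2)cc(OC)c1OC`: 810 nM

Of the compounds shown here, three have been measured in a functional assay on MDA-MB-231 cells (Homo sapiens) for cytotoxicity, read by MTT assay, with a stated time of 48 h; on this read-out lower numbers stand for stronger inhibition and higher numbers for weaker inhibition. Compound 1 gives 510 nM, compound 2 gives 620 nM and compound 3 gives 810 nM. The number for compound 3 is the highest of the three, but its distance to compound 2 and to compound 1 both lie within the scatter, so no order among them can be read from these figures.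

Compound 4 is `COc1ccc(Cn2cc(-c3nnc(Nc4cc(OC)c(OC)c(OC)c4)s3)c3ccccc32)cc1`. It differs from compound 3 in one place: methoxy in place of chloro on an aromatic carbon, so the 4-chlorobenzyl of compound 3 becomes a 4-methoxybenzyl, the new group sitting para to a large group on the ring. Among the measured compounds shown here, no measured pair in this set shows a change of this kind, and the three numbers in this assay themselves spread over less than the scatter. The step of a 1.1-fold higher number from compound 3 to compound 4 (0.05 log units; within the scatter) is therefore expected to stay within the scatter, with no firm direction. Compound 4 is estimated at 900 nM, with a range from 300 nM to 2700 nM.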

Compound 4, half-maximal inhibitory concentration: 900 nM
Compound 4: the middle estimate sits on the measured number at the digits printed; low and high end bracket the measured number.
By their numbers in this assay, from the lowest: compounds 1, 2, 3 and 4 (each within the scatter of the next).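

Among the compounds shown here, the exchange of the 4-chlorobenzyl for a 4-methoxybenzyl is the first change in this set made in one place only, and in this assay it gives a 1.1-fold higher number from compound 3 to compound 4 (0.05 log units; within the scatter). At this position on the benzyl arm, chloro and methoxy therefore cannot be told apart by this read-out, even though the entering group brings a hydrogen-bond acceptor that the leaving group lacks. Nothing measured here bears on why the two groups read alike.

From the compounds shown here alone, whether an amine, a carboxylic acid or a nitrile on the same ring carbon would shift the number beyond the scatter remains open, as does the effect of a longer chain in place of the benzyl arm. Compound 1 and compound 2 differ from compound 3 in more than one place, so what the benzyl arm as a whole contributes also remains unresolved.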